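Dichlorobenzimidazole series: bromo for sulfanyl on second core

A few compounds are considered here, and "the series" means these few. Any claim that something is new, unique, unknown or untested is made for them only; others in the source may bear on it.

Measured so far:
compound 1, `OCC(CO)OCn1c(S)nc2cc(Cl)c(Cl)cc21`: in a functional assay on KB cells (Homo sapiens) for inhibition (a higher number here means a weaker inhibitor, a lower number a stronger inhibitor), compound 1 gives > 100000 nM, a limit of the assay and not a number.
compound 2, `OCC(CO)OCn1c(S)nc2c(Cl)c(Cl)ccc21`: compound 2 gives > 100000 nM, again a limit.
compound 3, `OCC(CO)OCn1c(Br)nc2cc(Cl)c(Cl)cc21`: compound 3 gives > 100000 nM, also a limit.

All three values sit at the limit of > 100000 nM in this assay, at which 3 of the 3 values shown sit. The step from compound 1 to compound 3 is bromo in place of sulfanyl on an aromatic carbon; its size is a step that the two limits leave unreadable from compound 1 to compound 3. Compound 1 and compound 2 share the same atoms joined differently; the difference between the two cores is not broken down here.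

Compound 4, `OCC(CO)OCn1c(Br)nc2c(Cl)c(Cl)ccc21`, differs from compound 2 by bromo in place of sulfanyl on an aromatic carbon. This is the same change as that from compound 1 to compound 3, at the same place. Compound 4 is expected to sit at the limit as well, a step that the limit leaves unreadable from compound 2 to compound 4, because compound 2 gives > 100000 nM and compound 3 gives > 100000 nM. The expected value for compound 4 is 150000 nM, between 60000 nM and 500000 nM.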

Compound 4, half-maximal inhibitory concentration: > 100000 nM
Compound 4: a limit, no number; the forecaster's own chance of this, stated with the estimate: 85%; the middle value lies beyond the limit too.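

No step can be read from compound 2 to compound 4; both give a limit of the assay, not a number: the limit of > 100000 nM in this assay, at which 4 of the 4 values shown sit.

The compounds shown leave open whether bromo against sulfanyl, or one core against the other, changes inhibition at all.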